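Working notes: compound 4 against three analogues at a limit

The compounds below may be only part of what the source reports. "The series", "measured", "known", "first", "only" and "open" are said of these compounds alone.

Compound 1 `CCCCCc1ccc(NS(=O)(=O)c2ccc(N3CCNC3=O)cc2)cc1`, compound 2 `COc1ccc(NS(=O)(=O)c2ccc(N3CCNC3=O)cc2)cc1` and compound 3 `CC(C)Cc1ccc(NS(=O)(=O)c2ccc(N3CCNC3=O)cc2)cc1` share one core and differ only in the aryl group on the sulfonamide nitrogen. In a functional assay on MCF7 cells (Homo sapiens) for antiproliferative activity, read by sulforhodamine B assay, with a stated time of 48 h (a higher number here means a weaker inhibitor, a lower number a stronger inhibitor), compound 1 gives > 1000 nM, which is a limit of the assay. Compound 2 gives > 1000 nM, also a limit. Compound 3 gives > 1000 nM, again a limit. Thus a step that the two limits leave unreadable from compound 1 to compound 2, a step that the two limits leave unreadable from compound 1 to compound 3 and a step that the two limits leave unreadable from compound 2 to compound 3; all three values rest at the limit of > 1000 nM in this assay, at which 3 of the 3 values shown sit. Compound 4 `COc1ccccc1NS(=O)(=O)c1ccc(N2CCNC2=O)cc1` differs from compound 2 by 2-methoxyphenyl in place of 4-methoxyphenyl on a sulfonamide nitrogen. Among the compounds with values here, none of the measured steps has a readable size, so no direction beyond the scatter can be expected from them. Compound 4 is therefore expected to stay near the same limit, with an estimated step that the limit leaves unreadable from compound 2 to compound 4. Compound 4 is estimated at 3000 nM, within 800 nM to 30000 nM.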

Compound 4, half-maximal inhibitory concentration: 770 nM
Beside the measured number, compound 4's estimate is 3.9-fold (0.59 log units) above it; measured number outside the range, below it.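

In this assay, the exchange of 4-methoxyphenyl for 2-methoxyphenyl on a sulfonamide nitrogen gives an at least 1.2-fold lower number from compound 2 to compound 4 (0.11 log units; that floor lies within the scatter). Going by these compounds, the same atoms, joined differently, thus give a readable number, though the true size of the step stays unknown and the other steps cannot be read. Compound 4 alone stands off the limit: the limit of > 1000 nM in this assay, at which 3 of the 4 values shown sit.

The compounds shown leave open whether 2-ethoxyphenyl or 2-aminophenyl on the sulfonamide nitrogen would also give a readable number. They also leave open whether the gain holds with other groups at this place.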